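The source may hold more compounds than are shown below. What is called first, only, known or untested is meant among the compounds shown, and "the series" means these compounds.

Measured in a functional assay on HeLa cells (Homo sapiens) for cytotoxicity, read by MTT assay, with a stated time of 48 h; a lower number here means a stronger inhibitor, a higher number a weaker inhibitor:
- compound 1 `CC1(C)CCC[C@]2(C)[C@@H](CC[C@@](C)(O)/C=C/c3cncc4ccccc34)[C@](C)(O)CC[C@@H]12` gives 46000 nM
- compound 2 `Cc1cccc(/C=C/[C@](C)(O)CC[C@@H]2[C@@]3(C)CCCC(C)(C)[C@@H]3CC[C@@]2(C)O)c1C` gives 3700 nM
- compound 3 `COc1cccc(/C=C/[C@](C)(O)CC[C@@H]2[C@@]3(C)CCCC(C)(C)[C@@H]3CC[C@@]2(C)O)c1OC` gives 3880 nM

Compound 3 stands level with compound 2 and far under compound 1 in this assay. Next in the series is compound 4 `CC1(C)CCC[C@]2(C)[C@@H](CC[C@@](C)(O)/C=C/c3ccc(C(=O)O)cc3)[C@](C)(O)CC[C@@H]12`, which carries the change (4-carboxyphenyl in place of 2,3-dimethoxyphenyl on a double-bonded chain carbon bound to a double-bonded chain carbon). In words, this is 4-carboxyphenyl in place of 2,3-dimethoxyphenyl on a double-bonded chain carbon bound to a double-bonded chain carbon.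

Two measured steps at this same place bear on it. The first is a 1.0-fold higher number from compound 2 to compound 3 (0.02 log units; within the scatter), which shows that a swap of the aromatic group need not move the number. The second is a 12-fold lower number from compound 1 to compound 3 (1.07 log units; beyond the scatter), which shows that the same place can also carry a large step. Among the compounds with values here, no measured compound holds the 4-carboxyphenyl group, so neither step settles the direction. Within the data shown here, the only departure so far is upward, in compound 1 at 46000 nM, so a moderate step to a higher number is expected, smaller than the one between compound 1 and compound 3. The estimated step is a 3.6-fold higher number from compound 3 to compound 4 (0.56 log units; beyond the scatter). For compound 4 the estimated value is 14000 nM, with an expected range from 4000 nM to 50000 nM.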

Compound 4, half-maximal inhibitory concentration: 45400 nM
For compound 4 the middle estimate is 3.2-fold (0.51 log units) below the measured one; measured number inside the range.
By their numbers in this assay, from the lowest: compounds 2 and 3 (each within the scatter of the next); then compounds 4 and 1 (each within the scatter of the next).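

In this assay, the 4-carboxyphenyl group on a double-bonded chain carbon bound to a double-bonded chain carbon gives a 12-fold higher number from compound 3 to compound 4 (1.07 log units; beyond the scatter) and a 12-fold higher number from compound 2 to compound 4 (1.09 log units; beyond the scatter), so a large step away from the 2,3-dimethylphenyl and 2,3-dimethoxyphenyl compounds is no longer tied to the isoquinolin-4-yl group alone. With a 1.0-fold lower number from compound 1 to compound 4 (0.01 log units; within the scatter), the four compounds fall into two levels, compounds 2 and 3 in one and compounds 1 and 4 in the other, and a six-membered aromatic ring of carbon only at this place does not by itself place a compound in the lower-number level, as compound 4 shows. No measured evidence on hand accounts for either level.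

The compounds shown leave open whether the number in compound 4 follows the carboxylic acid itself or where it sits on the ring, a question that a 3-carboxyphenyl group, a 4-methoxyphenyl group, or the methyl ester or primary amide of the acid would help separate. They also leave open whether a plain unsubstituted phenyl group at this place would fall with compounds 2 and 3 or with compounds 1 and 4.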